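The source may report more compounds than this note shows. Statements on the series, on what has been measured and on what is new or still open speak of the compounds shown alone.

Measured so far in an assay on MDA-MB-231 cells for binding affinity to C-X-C chemokine receptor type 4 (Homo sapiens), read by immunofluorescence and microscopy, with stated times of 10 min and 30 min; a lower number here means that less compound is needed, a higher number that more compound is needed for the effect:
compound 1 `Cc1ccc(S(=O)(=O)NCc2ccc(CNC(=O)c3ccccc3)cc2)cc1` gives > 1000 nM, a limit of the assay rather than a number
compound 2 `COc1ccccc1C(=O)NCc1ccc(CNS(=O)(=O)c2ccccc2)cc1` gives 1 nM
compound 3 `O=C(NCc1ccc(CNS(=O)(=O)c2ccccc2)cc1)c1c(Cl)cc(Cl)cc1Cl` gives 10 nM

Compound 3 stands at the higher of the two numbers reported in this assay; its nearest neighbour is compound 2, and the counted step between them is a 10-fold higher number from compound 2 to compound 3 (1.00 log units; beyond the scatter), where 2,4,6-trichlorophenyl replaced 2-methoxyphenyl on the carbonyl carbon. Compound 1 sits at a limit, as noted in the limit of > 1000 nM in this assay, at which 1 of the 3 values shown sits, and so contributes no number to the comparison.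

Compound 4 `O=C(NCc1ccc(CNS(=O)(=O)c2ccccc2)cc1)c1ccccc1` is not yet measured. Its change from compound 3 is phenyl in place of 2,4,6-trichlorophenyl on a carbonyl carbon. Going by the values given here, the only measured step on this carbonyl substituent is the one from compound 2 to compound 3, which is modest in size and ran toward a higher number when the chlorinated ring entered. Removing the chlorines again is not the reverse of that step, since phenyl is not 2-methoxyphenyl, so the direction is uncertain. Among the compounds with values here, compound 1 also carries phenyl on the carbonyl carbon, with a different group on the sulfonyl, and reports only a limit; no step to it is counted here. Compound 4 is therefore expected to land somewhat above compound 3, at an estimated 30 nM with a range of 5 nM to 300 nM. This means an expected step of a 3.0-fold higher number from compound 3 to compound 4 (0.48 log units; beyond the scatter).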

Compound 4, effective concentration (reported as EC, without a stated level of effect): 1 nM
Compound 4: the middle estimate sits 30-fold (1.48 log units) above what was measured, outside the stated range (below it).
By their numbers in this assay, from the lowest: compounds 2 and 4 (each within the scatter of the next); then compound 3. At a limit, above all of these: compound 1.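

In this assay the unsubstituted phenyl on the carbonyl carbon gives up nothing, with a 10-fold lower number from compound 3 to compound 4 (1.00 log units; beyond the scatter) as phenyl replaces 2,4,6-trichlorophenyl, so the three chlorines are not needed for the low number and compound 3 is the one that stands apart in this set. Phenyl also matches the earlier best substituent, with hydrogen in place of methoxy on an aromatic carbon reading no change at the digits printed from compound 2 to compound 4 (within the scatter) and the methoxy therefore showing no measurable contribution here. The large change lies on the sulfonyl side, where hydrogen in place of methyl on an aromatic carbon gives an at least 1000-fold lower number from compound 1 to compound 4 (3.00 log units; beyond the scatter) and the value of compound 1 is only a limit: the limit of > 1000 nM in this assay, at which 1 of the 4 values shown sits.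

Whether a single chlorine already accounts for the step seen with 2,4,6-trichlorophenyl remains open, as does the effect of a carboxylic acid or an amine on the ring at the carbonyl carbon. Also open, going by these compounds, are the true size of the step from the methyl compound, which has no number, and whether a longer chain or a methoxy on the sulfonyl ring would behave like the methyl.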